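Chloro to bromo on the 4-chlorophenyl compound

This account rests on a few compounds, and the source may have more. Where it says the series, first, only, none or still open, it means among the compounds named here.

Compound 1 `CC(C)=CCOc1ccc2c(c1)OC(c1ccccc1F)CC2=O`: 6360 nM
Compound 2 `CC(C)=CCOc1ccc2c(c1)OC(c1ccc(Cl)cc1)CC2=O`: 6970 nM

In a functional assay (on this read-out lower numbers stand for stronger inhibition and higher numbers for weaker inhibition), compound 2 gives 6970 nM and stands level with compound 1 within the scatter. Compound 3 `CC(C)=CCOc1ccc2c(c1)OC(c1ccc(Br)cc1)CC2=O` differs from compound 2 by one change: bromo in place of chloro on an aromatic carbon. Going by the values given here, only one measured step bears on this, and it is not the same change: a 1.1-fold higher number from compound 1 to compound 2 (0.04 log units; within the scatter), with 4-chlorophenyl in place of 2-fluorophenyl on a saturated ring carbon. Among the compounds with values here, with that small step as the only guide and compound 2 at 6970 nM as the anchor, no move beyond the scatter is expected in this assay. The expected step is a 1.1-fold lower number from compound 2 to compound 3 (0.03 log units; within the scatter). For compound 3 the estimate is 6500 nM, with an expected range from 3300 nM to 12000 nM.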

Compound 3, half-maximal inhibitory concentration: 8120 nM
Compound 3: middle estimate off by 1.2-fold (0.10 log units), on the low side; measured number inside the range.
By their numbers in this assay, from the lowest: compounds 1, 2 and 3 (each within the scatter of the next).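

In this assay, bromo in place of chloro on an aromatic carbon, para to a large group, gives a 1.2-fold higher number from compound 2 to compound 3 (0.07 log units; within the scatter) and leaves the reading within the scatter. The comparison with the 2-fluorophenyl compound gives a 1.3-fold higher number from compound 1 to compound 3 (0.11 log units; within the scatter), so the 4-bromophenyl group also stands level with that group on the saturated ring carbon, and the three halogen-bearing phenyl groups shown cannot be told apart in this read-out. No measurement at hand accounts for this level reading.

Going by these compounds, all three compounds carry a single halogen on this phenyl ring, so it remains open whether a methoxy group, an amine or a carboxylic acid at the same place would give a step beyond the scatter. Also open, on these data alone, is whether a change elsewhere on the shared core would do so.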